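Turning the stilbene double bond from E to Z

This account rests on a few compounds, and the source may have more. Where it says the series, first, only, none or still open, it means among the compounds named here.

Three compounds carry a hydroxamic acid, the group most often relied on for inhibiting zinc-dependent deacetylases. Compound 1 `O=C(CCCCCCNC(=O)c1ccc(-c2ccc(-c3cc(O)cc(O)c3)cc2)cc1)NO` was included in the study, but in an assay on isolated protein for inhibition of protein deacetylase HDAC6 (Homo sapiens), read by fluorescence, with a stated time of 1 h (on this read-out lower numbers stand for stronger inhibition and higher numbers for weaker inhibition), compound 1 returned "not determined" (no result reported). Compound 2 `O=C(NO)c1ccc(-c2ccc(-c3cc(O)cc(O)c3)cc2)cc1` was included as well, and in this assay compound 2 likewise returned "not determined" (no result reported). Among the measured compounds shown here, compound 3 `COc1cc(/C=C/c2ccc(OC)c(NC(=O)CCCCCCC(=O)NO)c2)cc(OC)c1` is therefore the only compound with a number: in this assay compound 3 gives 1300 nM, which makes it the sole reference point for everything that follows.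

Compound 4 `COc1cc(/C=C\c2ccc(OC)c(NC(=O)CCCCCCC(=O)NO)c2)cc(OC)c1` is built from the same atoms and bonds as compound 3. The change is the two compounds have the same atoms and bonds and differ only in configuration as drawn: 1 of 1 stereo elements differ; a double bond is drawn E in compound 3 and Z in compound 4: the two compounds have the same atoms and bonds and differ only in configuration as drawn, with a double bond drawn E in compound 3 and Z in compound 4. For the measured compounds named here, no pair of measured compounds shows what such a switch does in this assay, so there is no step to lean on.

Because compound 3 gives 1300 nM and the change to compound 4 removes nothing and adds nothing, the expected step is a 1.2-fold higher number from compound 3 to compound 4 (0.06 log units; within the scatter), which would stay within the scatter. Compound 4 is therefore estimated at 1500 nM, within a range from 500 nM to 4500 nM.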

Compound 4, half-maximal inhibitory concentration: 1600 nM
For compound 4 the middle estimate is 1.1-fold (0.03 log units) below the measured one; the measured number falls inside the stated range.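

In this assay, turning the double bond from E to Z gives a 1.2-fold higher number from compound 3 to compound 4 (0.09 log units; within the scatter), so at this position the drawn geometry of the double bond produces no difference that can be told apart from the usual scatter of repeated measurements. Among the compounds shown here, until this pair, the set held a single number and no step at all, and compounds 1 and 2 offered nothing to compare, so this is the first reading of what any structural change does. The reading is also unusually clean, with no group leaving or entering, and the step can be tied to one difference only: the fact that compounds 3 and 4 differ only in the configuration as drawn.

The pair says nothing about what happens when the rest of the molecule changes, for example with a longer chain leading to the hydroxamic acid or a carboxylic acid in its place, as both parts stay fixed here. It also leaves open whether the double bond itself matters, which a saturated link in its place would test, and whether the same indifference to geometry would hold on any other deacetylase.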